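The compounds below may be only part of what the source reports. "The series", "measured", "known", "first", "only" and "open" are said of these compounds alone.

Series so far, in a functional assay on HL-60 cells (Homo sapiens) for cytotoxicity, read by WST assay, with a stated time of 48 h; a lower number here means a stronger inhibitor, a higher number a weaker inhibitor:
- compound 1 `COc1cc(C(c2ccc(O)c(OC)c2)[C@@H](CO)C(C)C)ccc1O`: > 100000 nM
- compound 2 `COc1cc(C(c2ccc(O)c(OC)c2)[C@@H](C)[C@H](C)CF)ccc1O`: 32000 nM
- compound 3 `CCCCC[C@H](C(C)C)C(c1ccc(O)c(OC)c1)c1ccc(O)c(OC)c1`: 9600 nM

The entry for compound 1 is a limit and not a number. Compound 3 carries the lowest number of the three, and both steps leading to it lie beyond the scatter: an at least 10-fold lower number from compound 1 to compound 3 (1.01 log units; beyond the scatter) and a 3.3-fold lower number from compound 2 to compound 3 (0.52 log units; beyond the scatter).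

Next in the series is compound 4 `COc1cc(C(c2ccc(O)c(OC)c2)[C@@H](CF)C(C)C)ccc1O`. The change from compound 3 is 1-(fluoromethyl)-2-methylpropyl in place of 1-isopropylhexyl on a saturated chain carbon bound to two aromatic carbons.

The closest guide is the modest step of a 3.3-fold lower number from compound 2 to compound 3 (0.52 log units; beyond the scatter), read in reverse, as compound 2 also carries a fluoromethyl group on a shorter chain than 1-isopropylhexyl. The step of an at least 3.1-fold lower number from compound 1 to compound 2 (0.49 log units; beyond the scatter) shows that a fluoromethyl group in place of the hydroxymethyl group of compound 1 goes with a lower number, so a return to the limit seen for compound 1 is not the central expectation. A modest move towards a higher number in this assay is therefore expected, estimated as a 3.6-fold higher number from compound 3 to compound 4 (0.56 log units; beyond the scatter). For compound 4 the expected value is 35000 nM, with an estimated range from 14000 nM to 90000 nM.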

Compound 4, half-maximal inhibitory concentration: 39000 nM
Compound 4: middle estimate off by 1.1-fold (0.05 log units), on the low side; the range from low to high includes it.
By their numbers in this assay, from the lowest: compound 3; then compounds 2 and 4 (each within the scatter of the next). At a limit, above all of these: compound 1.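

In this assay, 1-(fluoromethyl)-2-methylpropyl in place of 1-isopropylhexyl on a saturated chain carbon bound to two aromatic carbons gives a 4.1-fold higher number from compound 3 to compound 4 (0.61 log units; beyond the scatter), while the two fluorine-bearing groups at this place are not separated by the assay: a 1.2-fold higher number from compound 2 to compound 4 (0.09 log units; within the scatter). With only the fluoro in place of the hydroxy, the comparison gives an at least 2.5-fold lower number from compound 1 to compound 4 (0.40 log units; beyond the scatter), so this single exchange on the chain is enough to bring a measurable number into the series. Compound 1 stands at a limit and not a number, so this step gives only a bound: the limit of > 100000 nM in this assay, at which 1 of the 4 values shown sits.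

From the compounds shown here alone, it remains open whether the difference between compound 3 and compound 4 follows the length of the chain or the presence of the fluoro, and a longer chain than 1-isopropylhexyl, or a plain 1-isopropylpropyl group, would help to separate the two. Going by these compounds, how an amine or a carboxylic acid in place of the fluoro would read in this assay also stays open.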